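Dropping the ring chlorine from a short acyl thiourea

The compounds below may be only part of what the source reports. "The series", "measured", "known", "first", "only" and "open" are said of these compounds alone.

Compound 1 `CC(=O)NC(=S)Nc1ccc(Cl)cc1`: 2210 nM
Compound 2 `O=C(NC(=S)Nc1ccc(Cl)cc1)c1ccccc1`: 1640 nM

In an assay for inhibition of epoxide hydrolase 1 (Homo sapiens), read by fluorescence, using microsomes (on this read-out higher numbers stand for weaker inhibition and lower numbers for stronger inhibition), compound 1 gives 2210 nM, the higher of the two numbers, with compound 2 close by: a 1.3-fold lower number from compound 1 to compound 2 (0.13 log units; within the scatter). Compound 3 `CC(=O)NC(=S)Nc1ccccc1` differs from compound 1 by hydrogen in place of chloro on an aromatic carbon. Among the measured compounds shown here, the one measured step alters the group on the carbonyl carbon, not the aromatic ring, so nothing measured speaks to this change. Compound 3 is therefore expected to land near compound 1, with a wide range: 3500 nM, between 1200 nM and 12000 nM, an estimated step of a 1.6-fold higher number from compound 1 to compound 3 (0.20 log units; within the scatter).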

Compound 3, half-maximal inhibitory concentration: 2350 nM
Estimate against measurement, compound 3: 1.5-fold (0.17 log units) above; low and high end bracket the measured number.
By their numbers in this assay, from the lowest: compounds 2, 1 and 3 (each within the scatter of the next).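

Putting hydrogen in place of chloro, para to a group of 7 heavy atoms, gives a 1.1-fold higher number from compound 1 to compound 3 (0.03 log units; within the scatter) in this assay. With methyl on the carbonyl carbon, the ring chlorine is therefore not needed for a number of this size, and this change at this position makes no difference that can be told from the scatter. Nothing available explains this result. As far as these compounds go, it remains open whether the same change would behave alike with phenyl on the carbonyl carbon. From the compounds shown here alone, it also remains open whether a methoxy group or an amine at this ring position would move the number beyond the scatter.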